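Swapping 2-aminophenyl for methylcarbamoyl at the assay's limit

The source may hold more compounds than are shown below. What is called first, only, known or untested is meant among the compounds shown, and "the series" means these compounds.

Measured in a functional assay on blood (Homo sapiens), with a stated time of 60 min, in the presence of a further agent that is not named here; on this read-out lower numbers stand for an effect already at smaller amounts and higher numbers for an effect only at larger amounts of compound:
Compound 1 `Nc1ccc(-c2cccs2)cc1NC(=O)C1(S(=O)(=O)c2ccc(Oc3ccc(OC(F)(F)F)cc3)cc2)CCC2(CCNCC2)C1`: 900 nM
Compound 2 `Nc1ccccc1NC(=O)C1(S(=O)(=O)c2ccc(Oc3ccc(OC(F)(F)F)cc3)c(Cl)c2)CCC2(CCNCC2)C1`: 3700 nM
Compound 3 `COc1ccc(Oc2ccc(S(=O)(=O)C3(C(=O)Nc4ccccc4N)CCC4(CCNCC4)C3)cc2Cl)cc1`: > 15000 nM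

Compound 3 stands at the limit of > 15000 nM in this assay, at which 1 of the 3 values shown sits, so its entry is a limit and not a number. Compound 4 `CNC(=O)NC(=O)C1(S(=O)(=O)c2ccc(Oc3ccc(OC)cc3)c(Cl)c2)CCC2(CCNCC2)C1` carries methylcarbamoyl in place of 2-aminophenyl on an amide-type nitrogen. Among the measured compounds shown here, the only measured step, an at least 4.0-fold higher number from compound 2 to compound 3 (0.60 log units; beyond the scatter), is a change of methyl for trifluoromethyl on an oxygen on an aromatic ring. It does not touch the amide-type nitrogen, so it gives no size to carry over. No recovery beyond the scatter is therefore expected in this assay, and compound 4 is expected to stay around the limit. The expected change is a step that the limit leaves unreadable from compound 3 to compound 4. For compound 4 the estimated value is 20000 nM, with an expected range from 6000 nM to 60000 nM.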

Compound 4, half-maximal effective concentration: 3700 nM
The estimate for compound 4 lay 5.4-fold (0.73 log units) above the measured number; the whole stated range lies above it.
By their numbers in this assay, from the lowest: compound 1; then compounds 2 and 4 (each within the scatter of the next). At a limit, above all of these: compound 3.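

Methylcarbamoyl in place of 2-aminophenyl on the amide-type nitrogen gives an at least 4.0-fold lower number from compound 3 to compound 4 (0.60 log units; beyond the scatter) in this assay and is the only measured change at this position. Among the compounds shown here, the earlier step left this nitrogen untouched, so this result is the first sign that the position can move the read-out beyond the scatter. Going by these compounds, the value of compound 3 is a limit and not a number, so the true size of the step stays unknown.

On these data alone, whether the same swap holds with trifluoromethyl in place of methyl on the oxygen remains open. So does whether a longer chain than methyl on the carbamoyl, or an acetyl group on this nitrogen, would do the same.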